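A Trifluoromethyl Variant in a Hydroxamate Deacetylase Series

The source may report more compounds than this note shows. Statements on the series, on what has been measured and on what is new or still open speak of the compounds shown alone.

Compound 1, `Cc1cccc(-c2nc(CNc3ccc(C(=O)NO)cc3)n(-c3ccccc3)n2)c1`, gives 64.1% in an assay on Sf9 cells for inhibition of protein deacetylase HDAC6 (Homo sapiens), read by fluorescence, with a stated time of 40 min, tested at 100 nM; a lower number here means less inhibition, a higher number more inhibition at the concentration tested (going by the name of the read-out).
Compound 2, `Cc1ccc(-c2nc(CNc3ccc(C(=O)NO)cc3)n(-c3ccccc3)n2)cc1`, gives 62.2% in this assay.
Compound 3, `O=C(NO)c1ccc(NCc2nc(-c3ccc(F)cc3)nn2-c2ccccc2)cc1`, gives 70.9% in this assay.

Compound 3 carries the highest of the three numbers, yet its steps to the other two, a number 6.8 percentage points higher from compound 1 to compound 3 (within the scatter) and a number 8.7 percentage points higher from compound 2 to compound 3 (within the scatter), both lie within the scatter, as does a number 1.9 percentage points lower from compound 1 to compound 2 (within the scatter). Across these three compounds the group on the aromatic ring has been moved and exchanged without any shift that rises above repeat-to-repeat noise.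

Compound 4, `O=C(NO)c1ccc(NCc2nc(-c3ccc(C(F)(F)F)cc3)nn2-c2ccccc2)cc1`, is not yet measured. It differs from compound 3 by trifluoromethyl in place of fluoro on an aromatic carbon, so the 4-fluorophenyl becomes a 4-(trifluoromethyl)phenyl. Going by the values given here, the step that bears most directly on this is the exchange of fluoro for methyl at the same aromatic carbon, a number 8.7 percentage points higher from compound 2 to compound 3 (within the scatter), which stayed within the scatter; no measured pair shows a trifluoromethyl group, so the data give no direct precedent for it.

On this basis compound 4 is expected to sit close to compound 3, with an expected step of a number 4.9 percentage points lower from compound 3 to compound 4 (within the scatter) in this assay that does not exceed the scatter. Compound 4 is estimated at 66%, with a range from 50% to 80%.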

Compound 4, a percentage reported as inhibition, at one concentration (the size of the read-out at that concentration, not a potency): 41.6%
Compound 4: the middle estimate sits 24.4 percentage points above what was measured; measured number outside the range, below it.
By their numbers in this assay, from the lowest: compound 4; then compounds 2, 1 and 3 (each within the scatter of the next).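

In this assay, going by these compounds alone, the carbon para to a large group had so far taken fluoro and methyl with no shift beyond the scatter, but trifluoromethyl is the first group there to produce one: a number 29.3 percentage points lower from compound 3 to compound 4 (beyond the scatter) in place of fluoro and a number 20.6 percentage points lower from compound 2 to compound 4 (beyond the scatter) in place of methyl. The exchange of the 3-methylphenyl for the 4-(trifluoromethyl)phenyl gives a drop of similar kind, a number 22.5 percentage points lower from compound 1 to compound 4 (beyond the scatter), so compound 4 stands clearly apart from all three earlier compounds, which remain within the scatter of one another. Nothing available on these compounds accounts for this drop.

On these data alone, it remains open whether the loss is particular to trifluoromethyl or would also appear with a chlorine atom, a methoxy group or an ethyl group on the same carbon, and whether trifluoromethyl would give the same result on the ring carbon that carries the methyl in compound 1. Each number is also a reading at a single concentration, so how far these compounds differ in potency stays undetermined.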